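Vinyl in Place of Butyl on the Thiophene Amine

The source may report more compounds than this note shows. Statements on the series, on what has been measured and on what is new or still open speak of the compounds shown alone.

Compound 1 `CCCCc1csc(CN[C@@H]2C[C@H]3C[C@@H]([C@H]2C)C3(C)C)c1` gives 12500 nM in an ADME assay on MDCK cells (Canis lupus familiaris) for cytotoxicity, read by microscopy, with a stated time of 48 h (on this read-out higher numbers stand for lower toxicity in this test and lower numbers for higher toxicity in this test), the lowest of the two numbers shown. Compound 2 `C[C@H]1[C@H](NCc2ccc(Br)s2)C[C@H]2C[C@@H]1C2(C)C` gives 43000 nM in this assay, a higher number than compound 1. Compound 3 `C[C@H]1[C@H](NCc2cnccn2)C[C@H]2C[C@@H]1C2(C)C` reaches only a limit in this assay, > 100000 nM, which is the limit of > 100000 nM in this assay, at which 1 of the 3 values shown sits. Within the data shown here, the single measured step, an at least 2.3-fold higher number from compound 2 to compound 3 (0.36 log units; beyond the scatter), exchanges the aromatic ring bound to the amine and does not touch the substituent on the thiophene, so it does not bear on the present change. Compound 4 `C=Cc1csc(CN[C@@H]2C[C@H]3C[C@@H]([C@H]2C)C3(C)C)c1` differs from compound 1 as follows: vinyl in place of butyl on an aromatic carbon. Among the measured compounds shown here, no measured step covers this change, so only a small step is expected. Compound 4 is expected to give 20000 nM in this assay, with a range from 6000 nM to 60000 nM. The expected step is a 1.6-fold higher number from compound 1 to compound 4 (0.20 log units; within the scatter).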

Compound 4, minimum cytotoxic concentration: 6250 nM
For compound 4 the middle estimate is 3.2-fold (0.51 log units) above the measured one, within the range that was stated.
By their numbers in this assay, from the lowest: compounds 4 and 1 (each within the scatter of the next); then compound 2. At a limit, above all of these: compound 3.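

At the position two ring bonds from the ring sulfur, vinyl in place of butyl gives a 2.0-fold lower number from compound 1 to compound 4 (0.30 log units; within the scatter) in this assay. The thiophene amine therefore keeps its number within the scatter in this test when the 4 carbon chain gives way to the 2 carbon group with its double bond. Nothing in the evidence shown bears on this result. From the compounds shown here alone, whether an amine or a carboxylic acid at this position would move the number beyond the scatter remains open, and so does the effect of a chain longer than butyl.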